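A few compounds are considered here, and "the series" means these few. Any claim that something is new, unique, unknown or untested is made for them only; others in the source may bear on it.

Compound 1 `CCOC(=O)[C@@H]1CCCN(S(=O)(=O)c2ccc(S(=N)(=O)N(CC)CC)cc2)C1` gives > 10000 nM in a functional assay on MIA PaCa-2 cells (Homo sapiens) for inhibition, read by MTT assay, with a stated time of 3 days (on this read-out higher numbers stand for weaker inhibition and lower numbers for stronger inhibition), a limit of the assay rather than a number.
Compound 2 `CCN(CC)S(=O)(=O)c1ccc(S(=O)(=O)N2CCC[C@@H](C(=O)NC3COC3)C2)cc1` gives > 10000 nM in this assay, again a limit.
Compound 3 `CCOC(=O)C12CC(CN(S(=O)(=O)c3ccc(S(=O)(=O)N(CC)CC)cc3)C1)C2` gives > 10000 nM in this assay, also a limit.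

Going by the values given here, in this small set, then, no compound has yet produced a measured number: every value sits at the limit of > 10000 nM in this assay, at which 3 of the 3 values shown sit, and compound 1 stands there together with the other two. Because of the limit of > 10000 nM in this assay, at which 3 of the 3 values shown sit, nothing can be said about an order among the three, only that each of them inhibits these cells too weakly for the assay to report a figure.

Compound 4 `CCOC(=O)[C@@H]1CCCN(S(=O)(=O)c2ccc(S(=O)(=O)N3CCOCC3)cc2)C1` has not yet been tested. It keeps the core of compound 1 and changes one group on the aromatic ring: a group of 9 heavy atoms (4 carbon, 1 nitrogen, 3 oxygen, 1 sulfur; one six-membered non-aromatic ring with 2 hetero atoms) in place of a group of 8 heavy atoms (4 carbon, 2 nitrogen, 1 oxygen, 1 sulfur; no ring), on an aromatic carbon. Among the compounds with values here, no step between measured compounds is available, and the three values shown all sit at the limit, so there is no measured pair from which the size of such a change could be judged. The expectation for compound 4 in this assay is therefore that it will behave like compound 1, with no step beyond the scatter, that is a number no higher from compound 1 to compound 4 (the limit leaves the size open). Compound 4 is estimated at 10000 nM, with a range from 4000 nM to 30000 nM, most likely again reported only as a limit.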

Compound 4, half-maximal inhibitory concentration: > 10000 nM
Compound 4 was reported as a limit; the forecaster's own chance of this, stated with the estimate: 80%; the middle value sits exactly at the limit.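

Compound 1 and compound 4 both stay without a measured number in this assay, so no step can be read between them, because the values are limits only: the limit of > 10000 nM in this assay, at which 4 of the 4 values shown sit. The compounds shown leave open which change to the shared core, if any, would bring inhibition of these cells into a range that gives a measured figure.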